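A few compounds are considered here, and "the series" means these few. Any claim that something is new, unique, unknown or untested is made for them only; others in the source may bear on it.

The measured compounds and their values in a functional assay on MCF7 cells (Homo sapiens) for cytotoxicity, read by MTT assay, with a stated time of 24 h; on this read-out higher numbers stand for weaker inhibition and lower numbers for stronger inhibition:

Compound 1 `O=C(CN1CCN(c2ccccc2)CC1)N1CCN(c2nnc(-c3ccccc3)c(-c3ccccc3)n2)CC1`: in this assay compound 1 gives > 963000 nM, a limit of the assay and not a number.
Compound 2 `COc1ccc(-c2nnc(N3CCN(C(=O)CN4CCN(c5ccccc5Cl)CC4)CC3)nc2-c2ccc(OC)cc2)cc1`: in this assay compound 2 gives > 814000 nM, again a limit.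
Compound 3 `COc1ccc(-c2nnc(N3CCN(C(=O)CN4CCN(c5cccc(OC)c5)CC4)CC3)nc2-c2ccc(OC)cc2)cc1`: in this assay compound 3 gives > 821000 nM, also a limit.

Compound 3 therefore stands only at a limit in this assay, and the two further values shown are limits as well: one value sits at the limit of > 814000 nM in this assay, at which 1 of the 3 values shown sits, one at the limit of > 821000 nM in this assay, at which 1 of the 3 values shown sits, and one at the limit of > 963000 nM in this assay, at which 1 of the 3 values shown sits. None of the three is a number.

Compound 4 `COc1ccc(-c2nnc(N3CCN(C(=O)CN4CCN(c5ccc([N+](=O)[O-])cc5)CC4)CC3)nc2-c2ccc(OC)cc2)cc1` differs from compound 3 in one place: 4-nitrophenyl in place of 3-methoxyphenyl on an amine nitrogen in a ring. Going by the values given here, the single measured step between compounds that differ in one place, a step that the two limits leave unreadable from compound 2 to compound 3, runs between two limits and its size cannot be read. No readable step bears on the change from compound 3 to compound 4, so no size or direction of step can be derived from the measured compounds.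

Compound 4 is therefore expected to sit where compound 3 sits, at a limit in this assay, with an expected step that the limit leaves unreadable from compound 3 to compound 4 that is not distinguishable from none. The estimate for compound 4 in this assay is 900000 nM, within a range from 300000 nM to 3000000 nM.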

Compound 4, half-maximal inhibitory concentration: > 801000 nM
Compound 4 gave a limit, no number; the forecaster's own chance of this, stated with the estimate: 85%; the middle value is on the limit's open side.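

In this assay compound 4 gives > 801000 nM, which is a limit of the assay and not a number. Its steps from compound 2 and compound 3 therefore cannot be read. The compounds shown leave open whether 2-chlorophenyl, 3-methoxyphenyl or 4-nitrophenyl on the ring amine nitrogen makes any difference in this assay.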